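A few compounds are considered here, and "the series" means these few. Any claim that something is new, unique, unknown or untested is made for them only; others in the source may bear on it.

Measured compounds:
- compound 1, `COc1cc2c(Oc3ccc(NC(=O)c4nn(-c5cccc(F)c5)c(=O)cc4C)cc3F)ccnc2cc1OCCCN1CCC(C)CC1`: 300 nM
- compound 2, `COc1cc2c(Oc3ccc(NC(=O)c4nn(-c5ccc(Cl)cc5)c(=O)cc4C)cc3F)ccnc2cc1OCCCN1CCCC1`: 260 nM

Both compounds were tested in a functional assay on HT-29 cells (Homo sapiens) for inhibition, read by MTT assay, with a stated time of 72 h; a higher number here means a weaker inhibitor, a lower number a stronger inhibitor. In this assay compound 1 gives 300 nM and compound 2 gives 260 nM. These two numbers stand side by side: the gap between them is within the usual scatter of repeated measurements, so neither compound can be called the stronger inhibitor on this evidence. Compound 1 and compound 2 differ from each other in two places at once, so no single change can be read from the pair; the numbers only show that both sit in the same region.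

The next compound, compound 3, `COc1cc2c(Oc3ccc(NC(=O)c4nn(-c5ccc(Cl)cc5)c(=O)cc4C)cc3F)ccnc2cc1OCCCN1CCC(C)CC1`, keeps the core of compound 2 and changes one place: 4-methylpiperidin-1-yl in place of pyrrolidin-1-yl on a saturated chain carbon, three bonds along the chain from an oxygen on an aromatic ring. Going by the values given here, no measured pair isolates this change. Compound 1, however, already carries the 4-methylpiperidin-1-yl group and gives 300 nM, a value sitting with that of compound 2. The expectation is therefore a step of no size beyond the scatter, a 1.0-fold higher number from compound 2 to compound 3 (0.02 log units; within the scatter). Compound 3 is expected to give about 270 nM in this assay, with a range from 120 nM to 600 nM.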

Compound 3, half-maximal inhibitory concentration: 180 nM
Compound 3: middle estimate off by 1.5-fold (0.18 log units), on the high side, within the range that was stated.
By their numbers in this assay, from the lowest: compounds 3, 2 and 1 (each within the scatter of the next).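

Going by these compounds alone, compound 3 gives the first pair that isolates the group at the end of the chain. In this assay, a six-membered 4-methylpiperidin-1-yl ring in place of a five-membered pyrrolidin-1-yl ring gives only a small difference (a 1.4-fold lower number from compound 2 to compound 3 (0.16 log units; within the scatter)), so these two groups cannot be told apart here, at least with the 4-chlorophenyl group present. Compound 3 also isolates the group on the aromatic nitrogen, where 4-chlorophenyl in place of 3-fluorophenyl likewise stays inside the normal variation of the measurement (a 1.7-fold lower number from compound 1 to compound 3 (0.22 log units; within the scatter)), and no further data are available to explain either result.

The compounds shown therefore leave open how far this tolerance goes at the chain end, for example whether morpholin-4-yl, with an oxygen in the ring, or an open-chain dimethylamino group would stay in the same region, and whether a shorter ethyl link would do so. On these data alone, on the aromatic nitrogen, it also remains open whether an unsubstituted phenyl or a 4-methoxyphenyl group would produce a step larger than the scatter.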